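A few compounds are considered here, and "the series" means these few. Any claim that something is new, unique, unknown or untested is made for them only; others in the source may bear on it.

In a functional assay on the whole organism (strain Swiss) with Mus musculus as the target, in the maximal electroshock model, with a stated time of 2 h, at a dose of 300 mg/kg by the intraperitoneal route (a lower number here means a weaker effect, a higher number a stronger effect of the compound at the dose given), compound 1, `CCC(C(=O)N1CCN(c2ccccc2Cl)CC1)N1C(=O)CCC1=O`, gives 0%, while compound 2, `CC(C(=O)N1CCN(c2ccccc2C(F)(F)F)CC1)N1C(=O)CCC1=O`, gives 75%. Compound 2 thus stands highest of the two values known here, and its nearest neighbour, compound 1, lies far enough below it that the gap sits beyond the scatter. Within the data shown here, compound 1 and compound 2 differ in two places, so the two values alone show only that a pair of changes together moves the read-out a long way.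

Compound 3, `CCC(C(=O)N1CCN(c2ccccc2C(F)(F)F)CC1)N1C(=O)CCC1=O`, has not yet been measured. It differs from compound 2 in a single place: methyl in place of hydrogen on a saturated chain carbon, two bonds along the chain from an amide-type nitrogen in a ring and a carbonyl carbon. Compound 1 carries the same chain length as compound 3, but it also carries a different substituent on the aryl ring, so its value cannot be assigned to the chain alone.

Compound 3 is expected to lose part of the activity of compound 2, with the step of a number 35 percentage points lower from compound 2 to compound 3 (beyond the scatter) estimated as downward and beyond the scatter. The estimate for compound 3 in this assay is 40%, within a range from 0% to 80%.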

Compound 3, a percentage reported as activity, at one dose (the size of the read-out at that dose, not a potency): 0%
Compound 3: the middle estimate sits 40 percentage points above what was measured; low and high end bracket the measured number.
By their numbers in this assay, from the lowest: compounds 1 and 3 (each within the scatter of the next); then compound 2.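

In this assay, methyl in place of hydrogen on a saturated chain carbon, two bonds along the chain from an amide-type nitrogen in a ring and a carbonyl carbon, is enough by itself to remove the activity seen for compound 2, with a number 75 percentage points lower from compound 2 to compound 3 (beyond the scatter). With the ethyl chain end in place, trifluoromethyl in place of chloro on an aromatic carbon gives no change at the digits printed from compound 1 to compound 3 (within the scatter), so the aryl group that accompanies the activity of compound 2 does not restore it on this chain. Nothing available here explains why this single change has so large an effect.

From the compounds shown here alone, whether chloro would also be tolerated on the aromatic carbon with the shorter chain of compound 2 remains open. So does the response of this chain carbon to other groups, such as hydroxymethyl or an amine.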